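Working notes: configuration across three stereoisomers

The source may report more compounds than this note shows. Statements on the series, on what has been measured and on what is new or still open speak of the compounds shown alone.

- Compound 1 `Cc1cc(=O)c2c(OCC3CO3)cc(OCC3CO3)cc2o1`: 12100 nM
- Compound 2 `Cc1cc(=O)c2c(OC[C@H]3CO3)cc(OC[C@H]3CO3)cc2o1`: 229000 nM

Both values come from a functional assay on HCT-15 cells (Homo sapiens) for antiproliferative activity, with a stated time of 48 h; a higher number here means a weaker inhibitor, a lower number a stronger inhibitor. Compound 2 holds the higher of the two numbers, which makes it the weaker inhibitor of the pair. Among the measured compounds shown here, the only measured step is large and lies beyond the scatter: a 19-fold higher number from compound 1 to compound 2 (1.28 log units; beyond the scatter). That step goes with the fact that one of compounds 1 and 2 is drawn with a defined configuration and the other without, at the place where they differ.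

Compound 3 `Cc1cc(=O)c2c(OC[C@@H]3CO3)cc(OC[C@H]3CO3)cc2o1` is the next structure to read against compound 2: the two compounds have the same atoms and bonds and differ only in configuration as drawn: 1 of 2 stereo elements differ; a stereocentre at a saturated ring carbon is drawn R in compound 2 and S in compound 3. For the measured compounds named here, no measured step isolates the change at a single stereocentre, so the evidence is indirect. Compound 1 has no configuration drawn at its stereocentres, so its value need not belong to a single form. Since compound 1 gives 12100 nM, some form other than compound 2 may be clearly stronger, and compound 3 is a candidate. Part of a 19-fold higher number from compound 1 to compound 2 (1.28 log units; beyond the scatter) is therefore expected to be recovered, though the range must stay wide. The expected change is a 5.1-fold lower number from compound 2 to compound 3 (0.71 log units; beyond the scatter), towards a lower number. For compound 3 the estimated value is 45000 nM, with an expected range from 8000 nM to 200000 nM.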

Compound 3, half-maximal inhibitory concentration: 12100 nM
For compound 3 the middle estimate is 3.7-fold (0.57 log units) above the measured one, and the stated range covers the measured number.
By their numbers in this assay, from the lowest: compounds 1 and 3 (each within the scatter of the next); then compound 2.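

Changing a single saturated ring carbon stereocentre from R to S is now a measured change on its own: in this assay there is a 19-fold lower number from compound 2 to compound 3 (1.28 log units; beyond the scatter). Against the compound drawn without configuration, the S,R form shows no change at the digits printed from compound 1 to compound 3 (within the scatter), so the large difference seen earlier is not a general feature of drawing a defined configuration, and it depends on which configuration is drawn. The large step within the defined forms goes with configuration alone, with nothing else in the structure to account for it: the fact that compounds 2 and 3 differ only in the configuration as drawn

The compounds shown leave open how a form drawn S at both stereocentres would read, whether the same step appears when the other stereocentre changes, and which forms make up compound 1, whose value need not belong to a single form. They also leave open whether this dependence on configuration persists when a side chain on the shared core is replaced by an amine or a longer chain.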